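Furan for thiophene on a ribosylated core, tested on K562 cells

This account rests on a few compounds, and the source may have more. Where it says the series, first, only, none or still open, it means among the compounds named here.

Of the compounds shown here, three have been measured in a functional assay on K562 cells (Homo sapiens), read by MTT assay, with a stated time of 72 h; a higher number here means a weaker inhibitor, a lower number a stronger inhibitor. Compound 1 `Cc1nc(N)c2c(-c3ccoc3)cn([C@@H]3O[C@H](CO)[C@@H](O)[C@H]3O)c2n1` carries a furan-3-yl group; in this assay compound 1 gives > 20000 nM, which is a limit of the assay and not a number. Compound 3 `Cc1nc(N)c2c(-c3ccsc3)cn([C@@H]3O[C@H](CO)[C@@H](O)[C@H]3O)c2n1` carries a thiophen-3-yl group in the same place; in this assay compound 3 gives > 20000 nM, again a limit. Compound 2 `CNc1ncnc2c1c(-c1ccsc1)cn2[C@@H]1O[C@H](CO)[C@@H](O)[C@H]1O` shares its atoms with compound 3, joined differently; the difference between the two cores is not broken down here. In this assay compound 2 gives > 20000 nM, also a limit.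

Among the compounds with values here, the one change that recurs is furan-3-yl in place of thiophen-3-yl on an aromatic carbon. Between compound 3 and compound 1 it made a step that the two limits leave unreadable from compound 3 to compound 1, so its size cannot be read from those two measurements. All three values sit at the same boundary, as the limit of > 20000 nM in this assay, at which 3 of the 3 values shown sit, records, and nothing in them separates one compound from another.

Compound 4 `CNc1ncnc2c1c(-c1ccoc1)cn2[C@@H]1O[C@H](CO)[C@@H](O)[C@H]1O` has not been measured. It differs from compound 2 by furan-3-yl in place of thiophen-3-yl on an aromatic carbon, the same change seen from compound 3 to compound 1. Since that earlier step was unreadable and both of its partners stayed at the limit, the expected step from compound 2 to compound 4 is estimated as a step that the limit leaves unreadable from compound 2 to compound 4. On that basis compound 4 is expected to give about 40000 nM in this assay, most likely again reported only as a limit, with an estimated range from 15000 nM to 120000 nM.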

Compound 4, half-maximal inhibitory concentration: > 20000 nM
Compound 4: no number, only a limit; the forecaster's own chance of this, stated with the estimate: 90%; the middle value is on the limit's open side.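

In this assay compound 4 gives > 20000 nM, a limit of the assay and not a number. Compound 2 also stands at a limit, so the size of the change from thiophen-3-yl to furan-3-yl between compound 2 and compound 4 cannot be read. All the compounds now share one boundary: the limit of > 20000 nM in this assay, at which 4 of the 4 values shown sit.

The compounds shown leave open whether furan-3-yl and thiophen-3-yl differ at all in this assay.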